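The source may hold more compounds than are shown below. What is called first, only, known or untested is meant among the compounds shown, and "the series" means these compounds.

Compound 1 `Cc1nc(C#Cc2ccc(F)cc2)cs1`: 2970 nM
Compound 2 `Cc1nc(C#Cc2ccccc2F)cs1`: 140 nM

Of the two compounds measured in a functional assay on CHO cells for agonist activity at metabotropic glutamate receptor 5 (Homo sapiens), read by inositol phosphate accumulation (on this read-out higher numbers stand for weaker inhibition and lower numbers for stronger inhibition), compound 2 gives the lower number, 140 nM, while compound 1 gives 2970 nM; the gap between them is well beyond the usual scatter, so compound 2 stands as the stronger inhibitor of the pair. Compound 3 `COc1ccccc1C#Cc1csc(C)n1` has not yet been measured. It differs from compound 2 in one place: methoxy in place of fluoro on an aromatic carbon. Within the data shown here, no measured pair shows this exchange, so its effect here is not known from the data. The methoxy group brings one more heavy atom and one hydrogen-bond acceptor where the fluoro brought none, and a step of moderate size is expected, more likely toward a higher number than a lower one, though a result within the scatter cannot be excluded. For compound 3 the estimate is 320 nM, within 80 nM to 1500 nM, which is expected to mean a step of a 2.3-fold higher number from compound 2 to compound 3 (0.36 log units; beyond the scatter).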

Compound 3, half-maximal inhibitory concentration: 36.3 nM
For compound 3 the middle estimate is 8.8-fold (0.95 log units) above the measured one; the measured number lies below the stated range.
By their numbers in this assay, from the lowest: compound 3; then compound 2; then compound 1.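

In this assay the exchange of fluoro for methoxy on this aromatic carbon gives a 3.9-fold lower number from compound 2 to compound 3 (0.59 log units; beyond the scatter) and so runs toward stronger inhibition, even though methoxy brings more heavy atoms and a hydrogen-bond acceptor. This is the first exchange of one group for another at this place among the compounds shown, and it establishes that the group on this carbon can move the number beyond the scatter while the rest of the structure stays the same. No measurement at hand accounts for the direction of this step.

The compounds shown leave open whether ethoxy, hydroxyl or an amine on the same carbon would carry the number further or reverse the step. They also leave open whether methoxy would give a similar step elsewhere on the six-membered ring.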